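Acetyl replacing the sulfonyl group in compound 4

The source may report more compounds than this note shows. Statements on the series, on what has been measured and on what is new or still open speak of the compounds shown alone.

In a functional assay on HT-29 cells (Homo sapiens) for cytotoxicity, read by MTT assay, with a stated time of 96 h (on this read-out lower numbers stand for stronger inhibition and higher numbers for weaker inhibition), compound 1 (`COc1cc2c(cc1O)[C@@H]1CCc3cc(OC)c(OC)c(OC)c3[C@H]2CN1S(C)(=O)=O`) reads 11600 nM and compound 2 (`COc1cc2c(cc1O)[C@@H]1CCc3cc(OC)c(OC)c(OC)c3[C@H]2CN1S(=O)(=O)c1ccc(C)cc1`) reads 10800 nM while compound 3 (`COc1cc2c(c(OC)c1OC)[C@H]1CN(S(=O)(=O)c3ccc(C)cc3)[C@@H](CC2)C2=CC(=O)C(=O)C=C21`) reads 6600 nM in the same test. Compound 2 lies within the scatter of both other compounds, so it holds no distinct rank. Compound 4 (`COc1cc2c(cc1O)[C@@H]1CCc3cc(OC)c(OC)c(OC)c3[C@H]2CN1C(C)=O`) carries acetyl in place of (4-methylphenyl)sulfonyl on an amine nitrogen in a ring. Among the measured compounds shown here, the one measured step bearing on this is a 1.1-fold lower number from compound 1 to compound 2 (0.03 log units; within the scatter) and it changes only the group on the sulfonyl sulfur. For the measured compounds named here, no measured compound carries acetyl, so the guide is weak. The expected step is a 1.1-fold lower number from compound 2 to compound 4 (0.03 log units; within the scatter) and no shift beyond the scatter is expected in this assay here. For compound 4 the estimated value is 10000 nM (expected range 4000 nM to 25000 nM).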

Compound 4, half-maximal inhibitory concentration: > 50000 nM
Compound 4 was reported as a limit (the forecaster's own chance of this, stated with the estimate: 5%); middle value at least 5.0-fold (0.69 log units) away from the limit.
By their numbers in this assay, from the lowest: compounds 3, 2 and 1 (each within the scatter of the next). At a limit, above all of these: compound 4.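

In this assay, the group on this amine nitrogen does affect the read-out: compound 1 and compound 2 lie within the scatter of each other, yet acetyl in place of (4-methylphenyl)sulfonyl gives an at least 4.6-fold higher number from compound 2 to compound 4 (0.66 log units; beyond the scatter), and acetyl in place of methylsulfonyl gives an at least 4.3-fold higher number from compound 1 to compound 4 (0.63 log units; beyond the scatter). Among these compounds, changing the group on the sulfonyl sulfur shifts little, while replacing the whole sulfonyl group shifts much more. Compound 4 gives > 50000 nM, a limit and not a number.

Open, going by these compounds, is whether a free amine or a benzoyl group on this nitrogen reads like acetyl or like the sulfonyl compounds. Also open, on these data alone, is whether acetyl on the core of compound 3 gives a similar step.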